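The compounds below may be only part of what the source reports. "The series", "measured", "known", "first", "only" and "open" are said of these compounds alone.

Working notes on the series. Compound 1 `Cc1cc(C)c(S(C)(=O)=O)cc1C(=O)N=C(N)N`, compound 2 `CSc1cc(C)c(C(=O)N=C(N)N)cc1S(C)(=O)=O` and compound 3 `Cc1cc(OC(C)(C)C)c(S(C)(=O)=O)cc1C(=O)N=C(N)N` share one core and differ only in a substituent on an aromatic carbon. In a functional assay for inhibition of sodium/hydrogen exchanger (Oryctolagus cuniculus) (on this read-out lower numbers stand for stronger inhibition and higher numbers for weaker inhibition), compound 1 gives 11 nM, compound 2 gives 6 nM and compound 3 gives 9.4 nM. Compound 3 stands second highest of the three numbers, nearest compound 1 and furthest from compound 2, and all three lie within the scatter of one another: a 1.2-fold lower number from compound 1 to compound 3 (0.07 log units; within the scatter), a 1.6-fold higher number from compound 2 to compound 3 (0.19 log units; within the scatter) and a 1.8-fold lower number from compound 1 to compound 2 (0.26 log units; within the scatter). Compound 4 `Cc1cc(Oc2ccccc2)c(S(C)(=O)=O)cc1C(=O)N=C(N)N` is not yet measured and differs from compound 3 by phenyl in place of tert-butyl on an oxygen on an aromatic ring. Among the compounds with values here, no measured step exchanges the group on this oxygen, so the change has no direct precedent here; the steps that bear on it are those leading to compound 3, and both were small. Within the data shown here, with every step so far inside the scatter, no step beyond the scatter is expected in this assay for compound 4, in either direction. The expected step is a 1.1-fold higher number from compound 3 to compound 4 (0.03 log units; within the scatter). Compound 4 is estimated at 10 nM, with a range from 3.5 nM to 30 nM.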

Compound 4, half-maximal inhibitory concentration: 10 nM
The estimate for compound 4 equals the measured number at the digits printed, and the stated range covers the measured number.
By their numbers in this assay, from the lowest: compounds 2, 3, 4 and 1 (each within the scatter of the next).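

In this assay, within the data shown here, the oxygen on the aromatic ring carries a ring for the first time, and exchanging tert-butyl for phenyl stays within the scatter (a 1.1-fold higher number from compound 3 to compound 4 (0.03 log units; within the scatter)). Phenoxy also stays within the scatter of the other two groups on this aromatic carbon (a 1.1-fold lower number from compound 1 to compound 4 (0.04 log units; within the scatter); a 1.7-fold higher number from compound 2 to compound 4 (0.22 log units; within the scatter)), so methyl, methylsulfanyl, tert-butoxy and phenoxy have so far given no step beyond the scatter at this position. No evidence at hand bears on this result.

From the compounds shown here alone, whether an amine or a carboxylic acid at this position would also stay within the scatter remains open. Equally open, going by these compounds, is whether a longer chain or a substituted phenyl on the oxygen would give a step beyond the scatter in this assay.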